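This account rests on a few compounds, and the source may have more. Where it says the series, first, only, none or still open, it means among the compounds named here.

Compound 1 `O=C(O)c1cncc(-c2ccc(N3CCC(Oc4ccccc4C(F)(F)F)CC3)nn2)c1` gives the highest of the two numbers in an assay on isolated protein for inhibition of acyl-CoA desaturase 1 (Rattus norvegicus) (a lower number here means a stronger inhibitor, a higher number a weaker inhibitor), at 129 nM, while compound 2 `O=C(O)c1cncc(-c2ccc(N3CCC(Oc4cc(F)c(F)cc4Br)CC3)nn2)c1` gives 15 nM. Compound 3 `O=C(O)c1cncc(-c2ccc(N3CCC(Oc4cc(F)ccc4Br)CC3)nn2)c1` differs from compound 1 by 2-bromo-5-fluorophenyl in place of 2-(trifluoromethyl)phenyl on an oxygen on a saturated carbon. Among the measured compounds shown here, the one measured step that bears on this change is an 8.6-fold lower number from compound 1 to compound 2 (0.93 log units; beyond the scatter), where 2-bromo-4,5-difluorophenyl took the place of the same trifluoromethyl-bearing ring. Since compound 3 carries 2-bromo-5-fluorophenyl instead, a lower number is expected, though its size remains uncertain. Compound 3 is therefore estimated at 25 nM, between 10 nM and 65 nM, an expected step of a 5.2-fold lower number from compound 1 to compound 3 (0.71 log units; beyond the scatter).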

Compound 3, half-maximal inhibitory concentration: 15 nM
Compound 3: the middle estimate sits 1.7-fold (0.22 log units) above what was measured; the measured number falls inside the stated range.
By their numbers in this assay, from the lowest: compounds 2 and 3 (each within the scatter of the next); then compound 1.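

Hydrogen in place of fluoro on an aromatic carbon leaves the number in this assay where it stood (no change at the digits printed from compound 2 to compound 3 (within the scatter)), so the second fluoro of compound 2 is not needed to keep this level. With a single fluoro, 2-bromo-5-fluorophenyl in place of 2-(trifluoromethyl)phenyl still gives a clear gain (an 8.6-fold lower number from compound 1 to compound 3 (0.93 log units; beyond the scatter)). No measurement shown explains this result.

The compounds shown do not separate the contribution of the bromo from that of the remaining fluoro. As far as these compounds go, how a chloro or methoxy group would compare on this ring also remains open.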